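This account rests on a few compounds, and the source may have more. Where it says the series, first, only, none or still open, it means among the compounds named here.

Among the compounds with values here, in a functional assay on cells (Erythrocyte, Rattus norvegicus) for inhibition, read by hemolysis, with a stated time of 1 h (on this read-out higher numbers stand for weaker inhibition and lower numbers for stronger inhibition), compound 1 (`COc1ccc(C(=O)/C=C/c2cc(OC)c(OC)cc2OC)cc1`) gives 2.18 ug/mL and compound 2 (`COc1cc(OC)c(OC)cc1/C=C/C(=O)c1cc(Cl)ccc1O`) gives 2.23 ug/mL, so compound 1 stands within the scatter of the only other measured compound. Compound 3 (`COc1cc(OC)c(OC)cc1/C=C/C(=O)c1ccc([N+](=O)[O-])cc1`) keeps the core of compound 1 and carries one change: nitro in place of methoxy on an aromatic carbon, para to a large group. Within the data shown here, the only measured step, a 1.0-fold higher number from compound 1 to compound 2 (0.01 log units; within the scatter), alters the same ring and stays within the scatter. Among the measured compounds shown here, no nitro compound has been measured, so this is thin support, and no shift beyond the scatter is expected in this assay. The expected change is a 1.1-fold higher number from compound 1 to compound 3 (0.06 log units; within the scatter). Compound 3 is estimated at 2.5 ug/mL, with an expected range from 1 ug/mL to 6 ug/mL.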

Compound 3, half-maximal inhibitory concentration: 2.34 ug/mL
Compound 3: the middle estimate sits 1.1-fold (0.03 log units) above what was measured, and the stated range covers the measured number.
By their numbers in this assay, from the lowest: compounds 1, 2 and 3 (each within the scatter of the next).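

Nitro in place of methoxy on an aromatic carbon, para to a large group, gives a 1.1-fold higher number from compound 1 to compound 3 (0.03 log units; within the scatter) in this assay, so a single-group exchange at this position, with more heavy atoms and more hydrogen-bond acceptors entering, leaves the number within the scatter. Within the data shown here, the only earlier step changed the same ring at more than one place and could not show this for the position alone. No measurement bears on the reason for this result.

From the compounds shown here alone, whether an amine, a carboxylic acid or a longer alkoxy chain at this position would move the number beyond the scatter stays open. The compounds shown also leave open which part of the shared core, if any, governs the read-out.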